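Two Hydroxyalkyl Analogues and a Third Awaiting Measurement

A few compounds are considered here, and "the series" means these few. Any claim that something is new, unique, unknown or untested is made for them only; others in the source may bear on it.

Measured compounds:
compound 1, `O=c1cc(Cn2cc(C3CC3)nn2)c2ccc(O)cc2o1`, in a functional assay on CFPAC-1 cells (Homo sapiens) for inhibition, read by MTT assay, with a stated time of 72 h (on this read-out higher numbers stand for weaker inhibition and lower numbers for stronger inhibition), gives > 100000 nM, a limit of the assay rather than a number.
compound 2, `CC(O)c1cn(Cc2cc(=O)oc3cc(O)ccc23)nn1`, in this assay gives > 100000 nM, again a limit.

Compound 2 carries 1-hydroxyethyl in place of cyclopropyl on an aromatic carbon of compound 1. The step that the two limits leave unreadable from compound 1 to compound 2 cannot be read, since both values sit at the limit of > 100000 nM in this assay, at which 2 of the 2 values shown sit. Compound 2 therefore stands at the limit of this assay, with no measured number to place it against anything else.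

Compound 3, `O=c1cc(Cn2cc(CCCO)nn2)c2ccc(O)cc2o1`, differs from compound 2 by 3-hydroxypropyl in place of 1-hydroxyethyl on an aromatic carbon. Among the compounds with values here, no measured step involves a 3-hydroxypropyl group, so the only evidence that bears on this change is the pair of limits described by the limit of > 100000 nM in this assay, at which 2 of the 2 values shown sit, which gives neither a size nor a direction. Compound 3 is therefore expected to remain at the limit as well, a step that the limit leaves unreadable from compound 2 to compound 3 that cannot be told from none. The estimate for compound 3 in this assay is 150000 nM, with a range from 40000 nM to 600000 nM, most likely reported only as a limit.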

Compound 3, half-maximal inhibitory concentration: > 100000 nM
Compound 3: a limit, no number; the forecaster's own chance of this, stated with the estimate: 85%; the middle value does not contradict the limit.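

In this assay, within the data shown here, compound 3 also stands at a limit and not at a number, so no step among compound 1, compound 2 and compound 3 can be read. Going by these compounds, whether cyclopropyl, 1-hydroxyethyl and 3-hydroxypropyl differ from one another at all in this assay remains open, as do the size and direction of any such difference.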